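Methylamino in Place of Cyclopentyl: Expected Microsomal Stability

This account rests on a few compounds, and the source may have more. Where it says the series, first, only, none or still open, it means among the compounds named here.

Compound 1 `Cn1cc(-c2nc3c(-c4ccnc(OC5CC5)c4)cnn3cc2OCC(C)(C)O)cn1`: 81%
Compound 2 `COc1cc(-c2cnn3cc(OC)c(C4CCCC4)nc23)ccn1`: 7%
Compound 3 `COc1cn2ncc(-c3ccnc(OC(C)C)c3)c2nc1-c1cnn(C)c1`: 50%

Of the compounds shown here, three sharing one core have been measured in an ADME assay on microsomes from liver (Rattus norvegicus) for metabolic stability, with a stated time of 60 min, tested at 1 uM; on this read-out lower numbers stand for a less stable compound and higher numbers for a more stable compound. Compound 1 gives 81% and compound 3 gives 50%. Compound 2 stands at the bottom of these three numbers with 7%, a value that lies beyond the scatter below both compound 3 and compound 1. Among the measured compounds shown here, no two of the measured compounds differ in a single place, so no single step has yet been isolated.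

Compound 4 `CNc1nc2c(-c3ccnc(OC)c3)cnn2cc1OC` has not been measured. It is drawn from compound 2 by one change: methylamino in place of cyclopentyl on an aromatic carbon. The substituent that leaves is a five-membered non-aromatic ring of carbon only, and the one that enters carries a hydrogen-bond donor and an acceptor where the former had none.

Since compound 2 already sits at the low end of what has been seen, the expectation is for the step of a number 38 percentage points higher from compound 2 to compound 4 (beyond the scatter) to move upward, by an amount beyond the scatter, though the range of the other two compounds suggests the upper limit remains uncertain. On that basis compound 4 is expected to give about 45% in this assay, within a range from 15% to 75%.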

Compound 4, percent of the compound remaining: 74%
The estimate for compound 4 lay 29 percentage points below the measured number; measured number inside the range.
By their numbers in this assay, from the lowest: compound 2; then compound 3; then compounds 4 and 1 (each within the scatter of the next).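

Methylamino in place of cyclopentyl on an aromatic carbon gives a number 67 percentage points higher from compound 2 to compound 4 (beyond the scatter) in this assay, and this is the only step in the set confined to one place. It shows that this position, on a six-membered aromatic ring with 2 nitrogen, can alone carry a change of this size with the rest of compound 2 held fixed, which compound 1 and compound 3 could not show because each differs from compound 2 in more than one place. No measurement at hand accounts for the size of this step.

The compounds shown leave open which part of the change matters: cyclopentylamino would keep the ring while adding the nitrogen, ethyl would remove the ring without adding nitrogen, and dimethylamino would keep the nitrogen without its hydrogen. Also open, from the compounds shown here alone, is whether methylamino at this position would give a similar result alongside the other groups carried by compound 1 and compound 3.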